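Fluorophenyl variants on the shared core

The source may hold more compounds than are shown below. What is called first, only, known or untested is meant among the compounds shown, and "the series" means these compounds.

Compound 1 `C=CCn1c(=O)/c(=C\c2cccc(F)c2)[nH]c(=O)/c1=C\c1ccccc1OC` carries a 3-fluorophenyl and in a functional assay on U-937 cells (Homo sapiens) for cytotoxicity, read by CCK-8 assay, with a stated time of 72 h (on this read-out higher numbers stand for weaker inhibition and lower numbers for stronger inhibition), gives 2500 nM. Compound 2 `C=CCn1c(=O)/c(=C\c2ccc(C)cc2)[nH]c(=O)/c1=C\c1ccccc1OC` carries a 4-methylphenyl and in this assay gives "not active" (no number reported), with no number, so no single figure places compound 2. Compound 3 `C=CCn1c(=O)/c(=C\c2ccccc2F)[nH]c(=O)/c1=C\c1ccccc1OC` is not yet measured; it differs from compound 2 by 2-fluorophenyl in place of 4-methylphenyl on a double-bonded chain carbon bound to an aromatic carbon. Going by the values given here, no step between measured compounds covers this change, so its size is open; the expectation is a gain toward measurable activity, guided only by compound 1 with 2500 nM. Compound 3 is expected to give about 4000 nM, within 1000 nM to 20000 nM.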

Compound 3, half-maximal inhibitory concentration: 5500 nM
Beside the measured number, compound 3's estimate is 1.4-fold (0.14 log units) below it, and the stated range covers the measured number.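

In this assay, 2-fluorophenyl in place of 3-fluorophenyl on a double-bonded chain carbon bound to an aromatic carbon gives a 2.2-fold higher number from compound 1 to compound 3 (0.34 log units; beyond the scatter) and so moves toward weaker inhibition, showing that the read-out at this place responds to where the fluorine sits on the phenyl. Compound 3 gives a number where compound 2, with 4-methylphenyl, gives none, so the step between them cannot be read as a size. Open, from the compounds shown here alone, is whether an amine or a carboxylic acid in place of the fluorine would keep a measurable value, and whether the 2-fluorophenyl result holds with a longer chain in place of the allyl group. Nothing in hand accounts for the shift between the two fluorophenyl compounds.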